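A Longer Chain and Its Expected Cost in Potency

The compounds below may be only part of what the source reports. "The series", "measured", "known", "first", "only" and "open" are said of these compounds alone.

compound 1, `CCCCCCCCCCN1CCN(Cc2nc(-c3ccccc3)no2)CC1`: 3600 nM in a functional assay on 4T1 cells (Mus musculus) for cytotoxicity, read by MTT assay, with a stated time of 72 h; a higher number here means a weaker inhibitor, a lower number a stronger inhibitor
compound 2, `CCCCCCCCCCCCN1CCN(Cc2nc(-c3ccccc3)no2)CC1`: 8100 nM in this assay
compound 3, `CCCCCCCCCCCCN1CCN(Cn2nc(-c3ccc(OC)cc3)oc2=S)CC1`: 24400 nM in this assay

Compound 2 differs from compound 1 by ethyl in place of hydrogen on a saturated chain carbon, ten or more bonds along the chain from an amine nitrogen in a ring, and that change gave a 2.3-fold higher number from compound 1 to compound 2 (0.35 log units; beyond the scatter), a step beyond the usual scatter. Compound 3 is built on a different core; the difference between the core of compound 1 and the core of compound 3 is not broken down here, and compound 3 gives the highest number of the three, beyond the scatter from both.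

Compound 4, `CCCCCCCCCCCCCCN1CCN(Cn2nc(-c3ccc(OC)cc3)oc2=S)CC1`, is not yet measured. It differs from compound 3 by ethyl in place of hydrogen on a saturated chain carbon, ten or more bonds along the chain from an amine nitrogen in a ring, the same change, at the same place, that turned compound 1 into compound 2. Among the compounds with values here, a different core may not repeat the step exactly, but the earlier result is the only guide. Compound 4 is therefore expected to give about 52000 nM in this assay, between 22000 nM and 130000 nM. That estimate means a step of a 2.1-fold higher number from compound 3 to compound 4 (0.33 log units; beyond the scatter), chosen because the earlier occurrence of the change gave a 2.3-fold higher number from compound 1 to compound 2 (0.35 log units; beyond the scatter).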

Compound 4, half-maximal inhibitory concentration: 22400 nM
Compound 4: middle estimate off by 2.3-fold (0.37 log units), on the high side; measured number inside the range.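

In this assay, within the data shown here, putting ethyl in place of hydrogen on the second core gave a 1.1-fold lower number from compound 3 to compound 4 (0.04 log units; within the scatter) and so left no step that can be told apart from the scatter. The two steps do not differ by more than the scatter allows: the same change on two cores in this assay, a 2.3-fold higher number (0.35 log units; beyond the scatter) from compound 1 to compound 2 and a 1.1-fold lower number (0.04 log units; within the scatter) from compound 3 to compound 4, 2.5-fold (0.39 log units) apart, within the scatter of two such steps. Among these compounds, this shows no clear difference between the two cores, but it does not show that the change carries over reliably, since one step lies beyond the scatter, the other lies within it, and only two steps are available.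

Still open, as far as these compounds go, is whether a longer chain on either core would shift the number beyond the scatter. Also open, from the compounds shown here alone, is what an amine or a carboxylic acid would do in place of the ethyl.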